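The source may hold more compounds than are shown below. What is called first, only, known or untested is meant among the compounds shown, and "the series" means these compounds.

Measured compounds in a functional assay (Cavia porcellus) with Rattus norvegicus as the target; on this read-out lower numbers stand for an effect already at smaller amounts and higher numbers for an effect only at larger amounts of compound:

compound 1, `CCCOC1(c2ccc(Br)cc2)SC=C(C)n2c1noc2=O`, gives 410 nM
compound 2, `CCCCCCOC1(c2ccc(Br)cc2)SC=C(C)n2c1noc2=O`, gives 830 nM
compound 3, `CCCCCCCCCCCCCCCO[C@@]1(c2ccc(Br)cc2)SC=C(C)n2c1noc2=O`, gives 420 nM

Compound 4, `CCCCCCCCCCCCCCCCCCO[C@@]1(c2ccc(Br)cc2)SC=C(C)n2c1noc2=O`, is not yet measured in this assay.

From compound 1 to compound 2 the change is propyl in place of hydrogen on a saturated chain carbon, three bonds along the chain from an oxygen on a saturated carbon, and it brings a 2.0-fold higher number from compound 1 to compound 2 (0.31 log units; beyond the scatter). Compound 3 and compound 1 share the same core; the difference between the two cores is not broken down here. Compound 3 gives a number within the scatter of compound 1, and also within the scatter of compound 2, so no order can be read among these three.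

From compound 3 to compound 4 the change is propyl in place of hydrogen on a saturated chain carbon, ten or more bonds along the chain from an oxygen on a saturated carbon. Among the compounds with values here, this is the same kind of change as the one from compound 1 to compound 2, but the place along the chain differs, as the two descriptions of the change show. Within the data shown here, only one earlier step of this kind is at hand, and compound 3, with its much longer chain, sits within the scatter of both shorter-chain compounds. The step from compound 3 to compound 4 in this assay is therefore expected to be small, a 1.4-fold higher number from compound 3 to compound 4 (0.15 log units; within the scatter), with wide uncertainty. Compound 4 is estimated at 600 nM, expected between 250 nM and 1500 nM.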

Compound 4, half-maximal effective concentration: 970 nM
Beside the measured number, compound 4's estimate is 1.6-fold (0.21 log units) below it, and the stated range covers the measured number.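

Read in this assay with propyl in place of hydrogen on a saturated chain carbon, ten or more bonds along the chain from an oxygen on a saturated carbon, the change gives a 2.3-fold higher number from compound 3 to compound 4 (0.36 log units; beyond the scatter) and so goes the same way as the earlier step at three bonds along the chain. This shows the change carrying over on these two cores, but with one pair on each core it gives no rule for the series, and core and place along the chain vary together, so neither can be judged alone. The two steps do not differ in size: the same change on two cores in this assay, a 2.0-fold higher number (0.31 log units; beyond the scatter) from compound 1 to compound 2 and a 2.3-fold higher number (0.36 log units; beyond the scatter) from compound 3 to compound 4, 1.1-fold (0.06 log units) apart, within the scatter of two such steps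

Left open is whether the number keeps rising with a longer chain than that of compound 4. Also open, on these data alone, is whether the same step holds on a chain that carries an amine or a carboxylic acid.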